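The compounds below may be only part of what the source reports. "The series", "measured", "known", "first", "only" and "open" are said of these compounds alone.

Of the compounds shown here, three from one series have been tested in a functional assay on the whole organism (Tail, strain ICR) with Mus musculus as the target, in the tail flick test, with a stated time of 120 min, at a dose of 25 umol/kg by the oral route; on this read-out lower numbers stand for a weaker effect and higher numbers for a stronger effect at the one dose given. Compound 1, `O=C(CN(c1nc(Cl)nc2[nH]cnc12)C1CC1)N[C@@H](CO)C(=O)O`, gives 39% in this assay. Compound 2, `NC(=O)C[C@H](NC(=O)CN(c1nc(Cl)nc2[nH]cnc12)C1CC1)C(=O)O`, differs from compound 1 in one place: carbamoyl in place of hydroxy on a saturated chain carbon, two bonds along the chain from an amide-type nitrogen and a carbonyl carbon. This change produced a number 22 percentage points lower from compound 1 to compound 2 (beyond the scatter), so compound 2 gives 17% in this assay.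

Compound 3, `O=C(CN(c1ncnc2c1ncn2C1CCCCO1)C1CC1)N[C@@H](CO)C(=O)OCc1ccccc1`, is built on a different core, and the difference between the two cores is not broken down here. In this assay compound 3 gives 29.2%, which stands within the scatter of the value of compound 1 and beyond the scatter of the value of compound 2.

Compound 4, `NC(=O)C[C@H](NC(=O)CN(c1ncnc2c1ncn2C1CCCCO1)C1CC1)C(=O)OCc1ccccc1`, has not yet been measured in this assay. It differs from compound 3 by carbamoyl in place of hydroxy on a saturated chain carbon, two bonds along the chain from an amide-type nitrogen and a carbonyl carbon. Among the measured compounds shown here, this is the same change as the one from compound 1 to compound 2, at the same kind of place, so the earlier step is the only guide. Because that change gave a number 22 percentage points lower from compound 1 to compound 2 (beyond the scatter), a step of similar direction is expected from compound 3 to compound 4, though on a different core, and the expected step is a number 15.2 percentage points lower from compound 3 to compound 4 (beyond the scatter). The value for compound 4 is therefore estimated to be about 14%, most likely falling between 4% and 27%.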

Compound 4, a percentage reported as activity, at one dose (the size of the read-out at that dose, not a potency): 29.2%
Compound 4: the middle estimate sits 15.2 percentage points below what was measured; measured number above the stated range.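

In this assay, putting carbamoyl in place of hydroxy on the core of compound 3 gives no change at the digits printed from compound 3 to compound 4 (within the scatter), whereas the same change on the core of compound 1 gave a number 22 percentage points lower from compound 1 to compound 2 (beyond the scatter). The effect of this change therefore did not carry over from one core to the other, so in this series a step seen on one core cannot simply be added to a value on another: the same change on two cores in this assay, a number 22 percentage points lower (beyond the scatter) from compound 1 to compound 2 and no change at the digits printed (within the scatter) from compound 3 to compound 4, 22 percentage points apart, beyond the scatter of two such steps

Among the compounds shown here, this does not show which structural difference between the two pairs accounts for the gap, as the pairs differ from each other in more than one place, and it does not show why the change behaves differently; the comparison also rests on only two pairs, read at a single dose and a single time.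

The compounds shown leave open how an amine or a longer chain would behave in place of the hydroxy at this position on either core. For the compounds shown here, they also leave open whether the same change on a further core would follow the step seen with compound 2 or the one seen with compound 4.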